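The compounds below may be only part of what the source reports. "The series", "measured", "known", "first", "only" and "open" are said of these compounds alone.

Measured compounds:
Compound 1, `CCC(C)C(=O)Nc1c(C(O)(C(F)(F)F)C(F)(F)F)ccc2ccccc12`: 177000 nM
Compound 2, `O=C(Nc1c(C(O)(C(F)(F)F)C(F)(F)F)ccc2ccccc12)C1CC1`: 751 nM

In an assay on LtK cells with ATP-sensitive inward rectifier potassium channel 11 (Homo sapiens) as the target (on this read-out higher numbers stand for an effect only at larger amounts of compound and lower numbers for an effect already at smaller amounts), compound 2 gives 751 nM, the lower of the two numbers; compound 1 gives 177000 nM. Among the measured compounds shown here, the one measured step, a 240-fold lower number from compound 1 to compound 2 (2.37 log units; beyond the scatter), shows that the group on the carbonyl carbon alone can move the read-out a long way. Compound 3, `O=C(Nc1c(C(O)(C(F)(F)F)C(F)(F)F)ccc2ccccc12)c1ccc(Cl)cc1`, changes the same spot once more: 4-chlorophenyl in place of cyclopropyl on a carbonyl carbon. For the measured compounds named here, no measured step exchanges cyclopropyl for an aromatic ring, so the size of the step is open; the only guide is that this position is sensitive. With an aromatic ring of seven heavy atoms replacing a three-membered ring, compound 3 is expected to give a higher number than compound 2, an estimated step of a 4.0-fold higher number from compound 2 to compound 3 (0.60 log units; beyond the scatter). For compound 3 the expected value is 3000 nM, with a range from 300 nM to 30000 nM.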

Compound 3, half-maximal effective concentration: 570 nM
Compound 3: the middle estimate sits 5.3-fold (0.72 log units) above what was measured, and the stated range covers the measured number.
By their numbers in this assay, from the lowest: compounds 3 and 2 (each within the scatter of the next); then compound 1.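

In this assay, exchanging the group gives a 1.3-fold lower number from compound 2 to compound 3 (0.12 log units; within the scatter), so on this carbonyl carbon the readout does not separate cyclopropyl from 4-chlorophenyl, even though the two differ in ring size and heavy-atom count. Going from sec-butyl to the aromatic ring gives a 310-fold lower number from compound 1 to compound 3 (2.49 log units; beyond the scatter), so among these three compounds, both ring-bearing groups go with far lower numbers than the open-chain sec-butyl. No supporting measurement is available to explain this difference.

Among the compounds shown here, whether having a ring here is what really counts remains open, as only one open-chain group stands beside the two rings. Going by these compounds, what plain phenyl, cyclohexyl or a shorter chain such as ethyl would give on this carbonyl carbon is also open, as is whether the chlorine plays any part.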